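The compounds below may be only part of what the source reports. "The series", "measured", "known", "first", "only" and "open" are said of these compounds alone.

Measured to date in a functional assay on A549 cells (Homo sapiens) for antiproliferative activity, read by MTT assay, with a stated time of 48 h; a lower number here means a stronger inhibitor, a higher number a weaker inhibitor:

- compound 1 `Cc1ccc2[nH]c(-c3cn(-c4ccccc4)nc3-c3ccc(F)cc3)nc2c1`: 1440 nM
- compound 2 `Fc1ccc(-c2nn(-c3ccccc3)cc2-c2nc3cc(C(F)(F)F)ccc3[nH]2)cc1`: 2340 nM
- compound 3 `FC(F)(F)c1ccc2[nH]c(-c3cn(-c4ccccc4)nc3-c3ccc(Cl)cc3)nc2c1`: 3360 nM

Compound 1 and compound 2 share one core and differ by methyl in place of trifluoromethyl on an aromatic carbon. That change produced a 1.6-fold lower number from compound 2 to compound 1 (0.21 log units; within the scatter). Compound 3 is related to compound 2 by chloro in place of fluoro on an aromatic carbon, and that change gave a 1.4-fold higher number from compound 2 to compound 3 (0.16 log units; within the scatter). Compound 3 thus holds the highest number of the three; its gap to compound 2 is within the scatter, its gap to compound 1 is beyond it, so compound 1 and compound 3 can be ordered, but compound 2 cannot be placed firmly against either.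

Compound 4 `Cc1ccc2[nH]c(-c3cn(-c4ccccc4)nc3-c3ccc(Cl)cc3)nc2c1` has not yet been measured in this assay. It differs from compound 3 by methyl in place of trifluoromethyl on an aromatic carbon. This is the same change that separates compound 2 from compound 1, made at the same place on the same core, and among the four compounds it occurs twice in all. The step expected from compound 3 to compound 4 is a 1.6-fold lower number from compound 3 to compound 4 (0.20 log units; within the scatter), of about the size seen before, which rests on a 1.6-fold lower number from compound 2 to compound 1 (0.21 log units; within the scatter) in compound 2. A second line of reasoning starts from compound 1 with 1440 nM and adds the chloro-for-fluoro change measured as a 1.4-fold higher number from compound 2 to compound 3 (0.16 log units; within the scatter); it lands in the same region. Compound 4 is therefore expected at 2100 nM in this assay. For compound 4 the range expected is 1000 nM to 4500 nM.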

Compound 4, half-maximal inhibitory concentration: 4640 nM
Compound 4: the middle estimate sits 2.2-fold (0.34 log units) below what was measured, and the stated range ends below it.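

Methyl in place of trifluoromethyl, now carried over to the chloro-bearing pair, gives a 1.4-fold higher number from compound 3 to compound 4 (0.14 log units; within the scatter) in this assay, and the gap to the earlier step on the fluoro-bearing pair stays inside what two such steps can scatter: the same change on two cores in this assay, a 1.6-fold lower number (0.21 log units; within the scatter) from compound 2 to compound 1 and a 1.4-fold higher number (0.14 log units; within the scatter) from compound 3 to compound 4, 2.2-fold (0.35 log units) apart, within the scatter of two such steps. Chloro in place of fluoro gives a 3.2-fold higher number from compound 1 to compound 4 (0.51 log units; beyond the scatter) on the methyl-bearing pair, the only step of the four that lies beyond the scatter, yet it cannot be separated from the same change on the trifluoromethyl-bearing pair: the same change on two cores in this assay, a 1.4-fold higher number (0.16 log units; within the scatter) from compound 2 to compound 3 and a 3.2-fold higher number (0.51 log units; beyond the scatter) from compound 1 to compound 4, 2.2-fold (0.35 log units) apart, within the scatter of two such steps. Among the compounds shown here, the data therefore show no difference between cores for either change, but they do not show that either change transfers with a fixed size or direction, since each rests on only two pairs and the two methyl-for-trifluoromethyl steps, both within the scatter, give no direction that can be assigned.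

The compounds shown leave open how the series would read with a group other than methyl or trifluoromethyl at this place on the aromatic ring, such as a nitrile, a methoxy group or an amine. They also leave open whether a carboxylic acid or a longer chain there would produce steps large enough to stand clear of the scatter.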